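A few compounds are considered here, and "the series" means these few. Any claim that something is new, unique, unknown or untested is made for them only; others in the source may bear on it.

In a functional assay on HeLa cells (Homo sapiens) for antiproliferative activity, read by sulforhodamine B assay, with a stated time of 48 h (on this read-out higher numbers stand for weaker inhibition of growth and lower numbers for stronger inhibition of growth), compound 2 `COc1ccc(-c2nn(-c3ccccc3)cc2C(=O)NCc2cn(Cc3ccc(C(F)(F)F)cc3)nn2)cc1` gives 6200 nM, the lowest of the two numbers in hand, while compound 1 `COc1ccc(Cn2cc(CNC(=O)c3cn(-c4ccccc4)nc3-c3ccccc3)nn2)cc1OC` gives 10800 nM in this assay; the gap between these two lies within the scatter, so neither can be called the stronger of the pair. Among the compounds with values here, compound 1 and compound 2 differ in more than one place, so their two values show only that the shared core reaches this assay at a similar level with either arrangement. Compound 3 `COc1ccc(-c2nn(-c3ccccc3)cc2C(=O)NCc2cn(Cc3ccc(OC)c(OC)c3)nn2)cc1` has not yet been measured. It differs from compound 2 by 3,4-dimethoxyphenyl in place of 4-(trifluoromethyl)phenyl on a saturated chain carbon bound to an aromatic nitrogen. Within the data shown here, no step between measured compounds covers this change on its own. Compound 1 already carries the 3,4-dimethoxyphenyl on a saturated chain carbon bound to an aromatic nitrogen and gives 10800 nM in this assay, which suggests the change does not move the number far. Compound 3 is therefore expected to give about 8500 nM in this assay, with a likely range from 4000 nM to 18000 nM. The expected step of a 1.4-fold higher number from compound 2 to compound 3 (0.14 log units; within the scatter) is a small drift toward weaker inhibition, not clearly beyond the scatter.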

Compound 3, concentration for 50% growth inhibition: 800 nM
Estimate against measurement, compound 3: 11-fold (1.03 log units) above, outside the stated range (below it).
By their numbers in this assay, from the lowest: compound 3; then compounds 2 and 1 (each within the scatter of the next).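

In this assay, the step of a 7.8-fold lower number from compound 2 to compound 3 (0.89 log units; beyond the scatter) shows that the saturated chain carbon bound to an aromatic nitrogen is not indifferent to the aryl group it carries: 3,4-dimethoxyphenyl and 4-(trifluoromethyl)phenyl are clearly separated here, which compound 1 and compound 2, differing in more than one place, could not show. The second step, a 14-fold lower number from compound 1 to compound 3 (1.13 log units; beyond the scatter), comes with methoxy in place of hydrogen on an aromatic carbon, so compound 3 carries both this methoxy and the 3,4-dimethoxyphenyl, and taking away either one gives a step beyond the scatter. The data in hand offer no measurement that would explain either step.

The compounds shown leave open whether both methoxy groups of the 3,4-dimethoxyphenyl are needed, or whether a single methoxy on that ring would give a number as low as that of compound 3. They also leave open whether a hydroxy group, a chlorine atom or a dimethylamino group could stand in place of these methoxy groups, and whether a longer chain than the benzyl link would keep the lower number.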